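The source may hold more compounds than are shown below. What is called first, only, known or untested is meant among the compounds shown, and "the series" means these compounds.

Measured compounds:
compound 1 `Cc1ccc(/C=N\NC(=O)C2=C(Cl)c3ccccc3CCC2)cc1`: 2300 nM
compound 2 `COc1cccc(/C=N\NC(=O)C2=C(Cl)c3ccccc3CCC2)c1`: 15600 nM
compound 3 `Cc1cc2c(cc1C)C(Cl)=C(C(=O)N/N=C\c1ccc(Cl)cc1)CCC2`: 1600 nM

In a functional assay on HeLa cells (Homo sapiens) for inhibition, read by sulforhodamine B assay, with a stated time of 48 h (a higher number here means a weaker inhibitor of growth, a lower number a stronger inhibitor of growth), compound 3 stands at the low end of these three numbers. Its gap to compound 1 lies within the scatter, so the two cannot be told apart, while compound 2 sits well apart from both. Compound 4 `Cc1cc2c(cc1C)C(Cl)=C(C(=O)N/N=C\c1ccc(F)cc1)CCC2` has not yet been measured. It differs from compound 3 in one place: fluoro in place of chloro on an aromatic carbon. Among the compounds with values here, no measured step swaps one halogen for another on that ring. Within the data shown here, the only step in hand, a 6.8-fold higher number from compound 1 to compound 2 (0.83 log units; beyond the scatter), changes a group on the same ring and also moves it, so it is a loose guide; it shows that a change on this ring can shift the number by a modest amount. A swap of chloro for fluoro is a smaller change than that, so a step of a 1.6-fold higher number from compound 3 to compound 4 (0.19 log units; within the scatter) is expected to stay near the scatter. Compound 4 is therefore estimated at 2500 nM, with a range from 1000 nM to 6000 nM.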

Compound 4, concentration for 50% growth inhibition: 2200 nM
The estimate for compound 4 lay 1.1-fold (0.06 log units) above the measured number; measured number inside the range.
By their numbers in this assay, from the lowest: compounds 3, 4 and 1 (each within the scatter of the next); then compound 2.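

In this assay, the only halogen swap shown gives a 1.4-fold higher number from compound 3 to compound 4 (0.14 log units; within the scatter), so the 4-chlorophenyl and 4-fluorophenyl versions cannot be told apart. Within the data shown here, the earlier step, a 6.8-fold higher number from compound 1 to compound 2 (0.83 log units; beyond the scatter), showed only that changing a group on this ring and moving it at the same time can shift the number beyond the scatter, whereas this pair shows that, para to a large group, one halogen can stand in for the other with no readable shift. Nothing measured here explains why the two halogens read alike.

Still open, as far as these compounds go, is whether a larger halogen such as bromo, or a very different group such as an amine or a carboxylic acid, would hold the number in this range at this place. Also open, from the compounds shown here alone, is whether the same swap would read alike on the core of compound 1.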